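Replacing 3-nitrophenyl with 3,5-dimethoxyphenyl in compound 3

The source may report more compounds than this note shows. Statements on the series, on what has been measured and on what is new or still open speak of the compounds shown alone.

Compound 1 `O=C1/C(=C/c2cccc([N+](=O)[O-])c2)CN(S(=O)(=O)c2ccc(F)cc2)C/C1=C\c1cccc([N+](=O)[O-])c1`: 8760 nM
Compound 2 `O=C1/C(=C/c2cccc([N+](=O)[O-])c2)CN(S(=O)(=O)c2ccc(F)cc2)C/C1=C\c1ccccc1F`: 7040 nM
Compound 3 `COc1cc(/C=C2\CN(S(=O)(=O)c3ccc(F)cc3)C/C(=C\c3ccccc3F)C2=O)cc(OC)c1`: not yet measured

In a functional assay on HepG2 cells (Homo sapiens) for cytotoxicity, read by MTT assay, with a stated time of 24 h (a higher number here means a weaker inhibitor, a lower number a stronger inhibitor), compound 2 gives 7040 nM, which lies within the scatter of compound 1 at 8760 nM. Within the data shown here, the two compounds therefore stand level on the numbers so far. Compound 3 carries one change from compound 2: 3,5-dimethoxyphenyl in place of 3-nitrophenyl on a double-bonded chain carbon bound to a double-bonded ring carbon.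

Among the measured compounds shown here, only one measured step bears on this change: a 1.2-fold lower number from compound 1 to compound 2 (0.09 log units; within the scatter). There too a 3-nitrophenyl left a double-bonded chain carbon bound to a double-bonded ring carbon, with 2-fluorophenyl entering in its place. For the measured compounds named here, no measured compound yet carries 3,5-dimethoxyphenyl, so this single step offers limited guidance. On that evidence, no step beyond the scatter is expected, in either direction. The expected change is a 1.2-fold lower number from compound 2 to compound 3 (0.07 log units; within the scatter). For compound 3 the estimated value is 6000 nM, with an expected range of 2500 nM to 14000 nM.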

Compound 3, half-maximal inhibitory concentration: 9300 nM
Compound 3: middle estimate off by 1.6-fold (0.19 log units), on the low side; low and high end bracket the measured number.
By their numbers in this assay, from the lowest: compounds 2, 1 and 3 (each within the scatter of the next).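

In this assay, the step to 3,5-dimethoxyphenyl on a double-bonded chain carbon bound to a double-bonded ring carbon reads a 1.3-fold higher number from compound 2 to compound 3 (0.12 log units; within the scatter). This is the second exchange at such a place to stay within the scatter, and compound 3 no longer carries any 3-nitrophenyl, so neither 3-nitrophenyl group of compound 1 has been shown to matter to the number when exchanged for these groups. No measurement at hand speaks to a cause for this result.

The compounds shown leave open whether an amine or a carboxylic acid at this place would give a step beyond the scatter. They also leave open whether 2-fluorophenyl can be exchanged as freely as 3-nitrophenyl was, for instance for a longer chain.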